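Exchanging the chlorobenzyl arm for a carbamoylmethyl arm

This account rests on a few compounds, and the source may have more. Where it says the series, first, only, none or still open, it means among the compounds named here.

Measured so far:
compound 1 `Nc1nc(O)c2c(n1)n(C1OC(CO)[C@@H](O)[C@H]1O)c(=O)n2Cc1ccc(Cl)cc1`: 27%
compound 2 `Nc1nc(O)c2c(n1)n(C1OC(CO)[C@@H](O)[C@H]1O)c(=O)n2Cc1ccc(OCc2ccccc2)cc1`: 6%

In a functional assay on YAC-1 cells (Mus musculus) (on this read-out lower numbers stand for smaller maximal responses and higher numbers for larger maximal responses), compound 1 gives 27%, the highest of the two numbers measured. Among the measured compounds shown here, compound 2 gives 6%, and the only measured step, a number 21 percentage points lower from compound 1 to compound 2 (beyond the scatter), consists of benzyloxy in place of chloro on an aromatic carbon. Compound 3 `NC(=O)Cn1c(=O)n(C2OC(CO)[C@@H](O)[C@H]2O)c2nc(N)nc(O)c21` is not yet measured; relative to compound 1 its change is carbamoyl in place of 4-chlorophenyl on a saturated chain carbon bound to an aromatic nitrogen. For the measured compounds named here, the measured step varies a substituent while the aromatic ring remains; the step to compound 3 removes that ring altogether, so the single measured step bears on it only loosely. It shows that a change at this arm can shift the maximal response by a modest amount. For compound 3 a step of about a number 7 percentage points lower from compound 1 to compound 3 (within the scatter) is therefore expected, within the scatter. The maximal response of compound 3 is estimated at 20%, between 4% and 45%.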

Compound 3, largest response reached (reported as maximal response), in percent of the reference or control that the assay uses: 42%
For compound 3 the middle estimate is 22 percentage points below the measured one, within the range that was stated.
By their numbers in this assay, from the lowest: compound 2; then compound 1; then compound 3.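

In this assay, carbamoylmethyl in place of 4-chlorobenzyl gives a number 15 percentage points higher from compound 1 to compound 3 (beyond the scatter), so a response at this position does not depend on keeping an aromatic ring on the arm. The earlier change at this arm kept the ring and gave a number 21 percentage points lower from compound 1 to compound 2 (beyond the scatter); together, the two steps show that changes at this one arm can move the maximal response either down or up from compound 1. No measurement at hand gives a reason for the rise.

The compounds shown leave open whether the higher number comes from the carbamoyl group itself or simply from the loss of the 4-chlorophenyl ring. A carboxylic acid, a plain methyl or a longer chain ending in carbamoyl at this position could help separate those two readings.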